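Carboxylic acid replaces nitro on the pendant phenyl

The source may hold more compounds than are shown below. What is called first, only, known or untested is meant among the compounds shown, and "the series" means these compounds.

Measured compounds so far:
compound 1 `CC1=NC(C)=C(C(=O)O)C(c2ccccc2[N+](=O)[O-])/C1=C(\O)OC/C=C/c1ccccc1` — 37000 nM
compound 2 `CC1=NC(C)=C(C(=O)O)C(c2ccc([N+](=O)[O-])cc2)/C1=C(\O)OC/C=C/c1ccccc1` — 21000 nM
compound 3 `COC(=O)c1cccc(C2C(C(=O)O)=C(C)N=C(C)/C2=C(/O)OC/C=C/c2ccccc2)c1` — 4600 nM

All three were tested in a functional assay on IMR-32 cells for inhibition of Voltage-dependent N-type calcium channel subunit alpha-1B (Homo sapiens), read by calcium flux; on this read-out higher numbers stand for weaker inhibition and lower numbers for stronger inhibition. Compound 1 gives the highest number of the three; the nearest is compound 2, the furthest compound 3. The move a 1.8-fold lower number from compound 1 to compound 2 (0.25 log units; within the scatter) stays within the scatter, whereas an 8.0-fold lower number from compound 1 to compound 3 (0.91 log units; beyond the scatter) and a 4.6-fold lower number from compound 2 to compound 3 (0.66 log units; beyond the scatter) are modest but real shifts.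

Compound 4 `CC1=NC(C)=C(C(=O)O)C(c2cccc(C(=O)O)c2)/C1=C(\O)OC/C=C/c1ccccc1` is not yet measured. It differs from compound 1 in one place: 3-carboxyphenyl in place of 2-nitrophenyl on a saturated ring carbon. Among the measured compounds shown here, the only measured step that bears on it is the one from compound 1 to compound 3, since compound 3 also carries a 3-substituted phenyl, with a methoxycarbonyl group where compound 4 carries a carboxy group. For the measured compounds named here, no measured pair shows what swapping that ester for the acid does, so the size of that step is unknown. Given an 8.0-fold lower number from compound 1 to compound 3 (0.91 log units; beyond the scatter), compound 4 is expected to land somewhat below compound 1 in this assay, by an estimated 3.7-fold lower number from compound 1 to compound 4 (0.57 log units; beyond the scatter). The estimate for compound 4 is 10000 nM, with a range from 3000 nM to 35000 nM.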

Compound 4, half-maximal inhibitory concentration: 37000 nM
Compound 4: middle estimate off by 3.7-fold (0.57 log units), on the low side; the measured number lies above the stated range.
By their numbers in this assay, from the lowest: compound 3; then compounds 2, 1 and 4 (each within the scatter of the next).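

The pair of compound 3 and compound 4 isolates a single small change on the pendant phenyl: hydrogen in place of methyl on an oxygen next to a carbonyl group gives an 8.0-fold higher number from compound 3 to compound 4 (0.91 log units; beyond the scatter) in this assay and removes the advantage that compound 3 held over both nitrophenyl compounds. The 3-carboxyphenyl group does not separate from either of them, with no change at the digits printed from compound 1 to compound 4 (within the scatter) and a 1.8-fold higher number from compound 2 to compound 4 (0.25 log units; within the scatter), so in these compounds a substituent on that ring position does not by itself bring the lower number, and the methyl of the ester matters. No measurement shown offers a reason for this difference.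

On these data alone, it remains open whether an amide or an ethyl ester in place of the methyl ester would track compound 3 or compound 4. The same question stands for a hydroxymethyl group or an amine on this phenyl.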